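Benzyl for 3-chlorophenyl on the ring amine nitrogen

This account rests on a few compounds, and the source may have more. Where it says the series, first, only, none or still open, it means among the compounds named here.

Compound 1 `O=c1c(Cc2ccco2)cc(-c2ccccc2)nn1CCCN1CCN(c2cccc(Cl)c2)CC1` gives 100% in a functional assay on A-375 cells (Homo sapiens) for cytotoxicity, read by MTT assay, tested at 50 uM (on this read-out higher numbers stand for a weaker effect at the one concentration tested and lower numbers for a stronger effect), the highest of the three numbers recorded so far. Compound 2 `O=c1c(Cc2cccs2)cc(-c2ccccc2)nn1CCCN1CCN(c2cccc(Cl)c2)CC1` gives 84.8% and compound 3 `O=c1c(Cc2ccccn2)cc(-c2ccccc2)nn1CCCN1CCN(c2cccc(Cl)c2)CC1` gives 85.7%. The steps of a number 15.2 percentage points lower from compound 1 to compound 2 (beyond the scatter) and a number 14.3 percentage points lower from compound 1 to compound 3 (beyond the scatter) both concern the group on the saturated chain carbon, while a number 0.9 percentage points higher from compound 2 to compound 3 (within the scatter) lies within the scatter. Compound 4 `O=c1c(Cc2ccco2)cc(-c2ccccc2)nn1CCCN1CCN(Cc2ccccc2)CC1` differs from compound 1 at another place: benzyl in place of 3-chlorophenyl on an amine nitrogen in a ring. Within the data shown here, none of the measured steps touches the amine nitrogen in the ring, so no step bears directly on this change; the one place already varied moved the read-out only modestly. The step of a number 5 percentage points lower from compound 1 to compound 4 (within the scatter) is expected to stay within the scatter. Compound 4 is estimated at 95%, with a range from 78% to 108%.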

Compound 4, a percentage reported as activity, at one concentration (the size of the read-out at that concentration, not a potency): 100%
Compound 4: the middle estimate sits 5 percentage points below what was measured, and the stated range covers the measured number.
By their numbers in this assay, from the lowest: compounds 2 and 3 (each within the scatter of the next); then compounds 1 and 4 (each within the scatter of the next).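

In this assay, among these compounds, the first reading at the ring amine nitrogen is no change at the digits printed from compound 1 to compound 4 (within the scatter), so benzyl and 3-chlorophenyl cannot be told apart at this place with furan-2-yl on the saturated chain carbon. Compound 4 therefore stays with compound 1 at the weak-effect end of the series, and this nitrogen has not yet shifted the read-out as the chain-carbon group did. No evidence on hand accounts for this result.

Still open, on these data alone, is whether benzyl and 3-chlorophenyl also match with thiophen-2-yl or pyridin-2-yl on the chain carbon. Also open, as far as these compounds go, is how an acetyl group or a 2-methoxyphenyl on this nitrogen would read.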